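The source may hold more compounds than are shown below. What is called first, only, known or untested is meant among the compounds shown, and "the series" means these compounds.

Measured so far in a functional assay on MKN-45 cells (Homo sapiens) for inhibition, read by MTT assay, with a stated time of 72 h; on this read-out lower numbers stand for stronger inhibition and higher numbers for weaker inhibition: compound 1 `COc1cc2c(Oc3ccc(NC(=O)c4nn(-c5ccccc5)c(=O)cc4C)cc3F)ccnc2cc1OCCCN1CCN(C)CC1`, 130 nM; compound 2 `COc1cc2c(Oc3ccc(NC(=O)c4nn(-c5ccccc5OC(F)(F)F)c(=O)cc4C)cc3F)ccnc2cc1OCCCN1CCN(C)CC1`, 100 nM; compound 3 `COc1ccc(-n2nc(C(=O)Nc3ccc(Oc4ccnc5cc(OCCCN6CCCCC6)c(OC)cc45)c(F)c3)c(C)cc2=O)cc1`, 330 nM.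

Compound 3 gives the highest number of the three, beyond the scatter from both compound 1 and compound 2. Compound 4 `COc1ccc(-n2nc(C(=O)Nc3ccc(Oc4ccnc5cc(OCCCN6CCN(C)CC6)c(OC)cc45)c(F)c3)c(C)cc2=O)cc1` differs from compound 3 by 4-methylpiperazin-1-yl in place of piperidin-1-yl on a saturated chain carbon, three bonds along the chain from an oxygen on an aromatic ring. Going by the values given here, no measured step covers this change; the only measured step, a 1.3-fold lower number from compound 1 to compound 2 (0.11 log units; within the scatter), concerns a different place and lies within the scatter. Compounds 1 and 2 both carry the entering group and give lower numbers than compound 3, but they also differ from it elsewhere, so this is only a loose hint. A modest lowering is therefore expected, about a 1.5-fold lower number from compound 3 to compound 4 (0.18 log units; within the scatter) in this assay, with wide uncertainty. Compound 4 is estimated at 220 nM, in the range 90 nM to 550 nM.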

Compound 4, half-maximal inhibitory concentration: 1230 nM
Compound 4: the middle estimate sits 5.6-fold (0.75 log units) below what was measured, and the stated range ends below it.
By their numbers in this assay, from the lowest: compounds 2 and 1 (each within the scatter of the next); then compound 3; then compound 4.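

In this assay, this position on the chain proves sensitive: 4-methylpiperazin-1-yl in place of piperidin-1-yl gives a 3.7-fold higher number from compound 3 to compound 4 (0.57 log units; beyond the scatter), so the lower numbers of the two earlier compounds carrying this amine did not come from the amine alone. With that amine held constant, the group on the aromatic nitrogen also matters, with a 9.5-fold higher number from compound 1 to compound 4 (0.98 log units; beyond the scatter) for methoxy in place of hydrogen and a 12-fold higher number from compound 2 to compound 4 (1.09 log units; beyond the scatter) for 4-methoxyphenyl in place of 2-(trifluoromethoxy)phenyl. Nothing available here explains these steps. Going by these compounds, whether the amine swap acts the same way with phenyl or 2-(trifluoromethoxy)phenyl on that nitrogen remains open. So does how morpholin-4-yl, or a longer chain, would read at this position.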